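Working notes: from compound 3 to compound 4

The source may report more compounds than this note shows. Statements on the series, on what has been measured and on what is new or still open speak of the compounds shown alone.

Measured in a functional assay on CHO-K1 cells for antagonist activity at transient receptor potential cation channel subfamily V member 1 (Homo sapiens), read by FLIPR; a lower number here means a stronger inhibitor, a higher number a weaker inhibitor:
- compound 1 `CC(C(=O)NCc1ccc(C(F)(F)F)nc1NC1CCCCC1)c1ccc(NS(C)(=O)=O)c(F)c1`: 20.4 nM
- compound 2 `CC(C(=O)NCc1ccc(C(F)(F)F)nc1NCc1ccccc1)c1ccc(NS(C)(=O)=O)c(F)c1`: 15.8 nM
- compound 3 `CC(C(=O)NCc1ccc(C(F)(F)F)nc1N1CCC(C(F)(F)F)CC1)c1ccc(NS(C)(=O)=O)c(F)c1`: 0.6 nM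

Compound 3 holds the lowest number of the three; the nearer of its two gaps is a 26-fold lower number from compound 2 to compound 3 (1.42 log units; beyond the scatter), and the wider one is a 34-fold lower number from compound 1 to compound 3 (1.53 log units; beyond the scatter). Between the other two compounds the step is a 1.3-fold lower number from compound 1 to compound 2 (0.11 log units; within the scatter).

Compound 4 `CC(C(=O)NCc1ccc(C(F)(F)F)nc1N1CCC(CN(C)C)CC1)c1ccc(NS(C)(=O)=O)c(F)c1` differs from compound 3 in one place: (dimethylamino)methyl in place of trifluoromethyl on a saturated ring carbon. Going by the values given here, no measured step touches this position. The two large steps into compound 3 each bring in the whole 4-(trifluoromethyl)piperidin-1-yl group at once, so they cannot tell how much of the gain rests on the trifluoromethyl itself and how much on the ring attachment; the change from cyclohexyl to benzyl bears on another part of the molecule. The expectation for compound 4 is therefore a loss of some of the advantage of compound 3, read as an 8.3-fold higher number from compound 3 to compound 4 (0.92 log units; beyond the scatter) in this assay, with wide uncertainty. In this assay compound 4 is estimated at 5 nM, within 0.8 nM to 30 nM.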

Compound 4, inhibition constant: 2.1 nM
Compound 4: middle estimate off by 2.4-fold (0.38 log units), on the high side, and the stated range covers the measured number.
By their numbers in this assay, from the lowest: compound 3; then compound 4; then compounds 2 and 1 (each within the scatter of the next).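

In this assay the saturated ring carbon accepts (dimethylamino)methyl in place of trifluoromethyl at a modest cost (a 3.5-fold higher number from compound 3 to compound 4 (0.54 log units; beyond the scatter)), so the large gain seen with compound 3 does not depend on trifluoromethyl alone. The 4-((dimethylamino)methyl)piperidin-1-yl group still keeps a clear lead over benzylamino (a 7.5-fold lower number from compound 2 to compound 4 (0.88 log units; beyond the scatter)) and over cyclohexylamino (a 9.7-fold lower number from compound 1 to compound 4 (0.99 log units; beyond the scatter)), which shows that a second kind of substituent on this ring can retain much of the advantage. No measurement at hand offers a reason for either the cost or the retained gain.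

Still open, as far as these compounds go, is how a plain piperidin-1-yl, with only hydrogen on that ring carbon, would compare with these two groups, and so how much of the gain belongs to the ring itself. A hydroxyl, a carboxylic acid or a longer chain ending in an amine at the same carbon would show how widely this position accepts change.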